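N-substituent variation on a thiophenylmethyl aryloxyacetamide series

A few compounds are considered here, and "the series" means these few. Any claim that something is new, unique, unknown or untested is made for them only; others in the source may bear on it.

Measured so far:
- compound 1 `CON(Cc1cccs1)C(=O)COc1ccc(C)cc1`: 10 nM
- compound 2 `CCN(Cc1cccs1)C(=O)COc1cccc(C)c1`: 97 nM

In an assay on HEK293 cells for agonist activity at transient receptor potential cation channel subfamily M member 8 (Homo sapiens), read by fluorescence and calcium flux, with a stated time of 15 min (a lower number here means that less compound is needed, a higher number that more compound is needed for the effect), compound 1 gives 10 nM, the lowest of the two numbers in hand. For the measured compounds named here, compound 2 gives 97 nM in this assay, a higher number that lies beyond the scatter of the measurement; the two compounds differ at the amide nitrogen and in the position of the methyl group on the aryl ether, so the two values show only that one of these changes, or both together, costs potency.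

Compound 3 `Cc1ccc(OCC(=O)N(Cc2cccs2)c2ccn[nH]2)cc1` is not yet measured in this assay. It keeps the core of compound 1 and changes only the substituent on the amide nitrogen: 1H-pyrazol-5-yl in place of methoxy on an amide-type nitrogen. A single small group is thus exchanged for a larger aromatic heterocycle carrying a hydrogen-bond donor at the same place.

Going by the values given here, no measured pair isolates this change. The step from compound 1 to compound 2 suggests that altering the amide nitrogen substituent can raise the number, but it is confounded by the ring methyl shift. The step of a 6.0-fold higher number from compound 1 to compound 3 (0.78 log units; beyond the scatter) is expected to be a moderate loss, with wide uncertainty. Compound 3 is therefore estimated at 60 nM in this assay, within a range of 10 nM to 400 nM.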

Compound 3, half-maximal effective concentration: 0.2 nM
Beside the measured number, compound 3's estimate is 300-fold (2.48 log units) above it, and the stated range ends above it.
By their numbers in this assay, from the lowest: compound 3; then compound 1; then compound 2.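

In this assay the amide nitrogen proves to be a highly sensitive position, and the change from methoxy to 1H-pyrazol-5-yl gives a 50-fold lower number from compound 1 to compound 3 (1.70 log units; beyond the scatter) with the rest of compound 1 held fixed. Unlike the earlier comparison, this step isolates the substituent on the amide-type nitrogen, and it shows that a larger aromatic heterocycle is not merely accepted there but is accompanied by a much lower number. The step adds heavy atoms, a five-membered aromatic ring and a hydrogen-bond donor all at once, and no measurement shown assigns the gain to any one of these or explains it.

Still open, on these data alone, is whether the ring alone carries the gain or the hydrogen-bond donor is also needed; a phenyl ring at this place, or a pyrazolyl ring with a methyl group in place of its ring hydrogen, would separate the two. Also open, as far as these compounds go, is whether the 1H-pyrazol-5-yl group gives a similar step on the aryl ether pattern of compound 2, which would show how far the effect extends beyond the core of compound 1.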